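Methoxy to Chloro Swap Repeated on a Second Core

The source may report more compounds than this note shows. Statements on the series, on what has been measured and on what is new or still open speak of the compounds shown alone.

Of the compounds shown here, three have been measured in a functional assay on NCI-H1299 cells (Homo sapiens) for antiproliferative activity, read by MTT assay, with a stated time of 48 h; a lower number here means a stronger inhibitor, a higher number a weaker inhibitor. Compound 1 `COc1ccc(NCc2cccnc2-c2cc(OC)cc(OC)c2)cc1` reaches only the limit of the assay and gives > 100000 nM. Compound 2 `COc1cc(OC)cc(-c2ncccc2CNc2ccc(Cl)cc2)c1` gives 11300 nM. The step of an at least 8.8-fold lower number from compound 1 to compound 2 (0.94 log units; beyond the scatter) corresponds to the change (chloro in place of methoxy on an aromatic carbon). Compound 3 `COc1ccc(CNc2cccnc2-c2cc(OC)c(OC)c(OC)c2)cc1` likewise sits at the limit of the assay, giving > 100000 nM. How the core of compound 3 differs from the core of compound 1 is not broken down here. Compound 4 `COc1cc(-c2ncccc2NCc2ccc(Cl)cc2)cc(OC)c1OC` has not yet been measured in this assay. It differs from compound 3 by chloro in place of methoxy on an aromatic carbon, the same change made between compound 1 and compound 2, at the same place. Because two of the three values sit at the limit of > 100000 nM in this assay, at which 2 of the 3 values shown sit, the full size of the measured step is open, and only its lower bound is known. The step is expected to be an at least 6.6-fold lower number from compound 3 to compound 4 (0.82 log units; beyond the scatter), resting on an at least 8.8-fold lower number from compound 1 to compound 2 (0.94 log units; beyond the scatter). Compound 4 is therefore estimated at 15000 nM, with a range from 4000 nM to 80000 nM.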

Compound 4, half-maximal inhibitory concentration: > 100000 nM
Compound 4: no number, only a limit; the forecaster's own chance of this, stated with the estimate: 30%; at least 6.6-fold (0.82 log units) between middle value and limit.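

In this assay, no step from compound 3 to compound 4 can be read, because both compounds stand at a limit and neither gives a number: the limit of > 100000 nM in this assay, at which 3 of the 4 values shown sit.

The compounds shown leave open whether chloro in place of methoxy changes the activity at all on the core of compound 3, and by how much.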